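Swapping an Octyl Chain for Phenyl on the Ring Nitrogen

A few compounds are considered here, and "the series" means these few. Any claim that something is new, unique, unknown or untested is made for them only; others in the source may bear on it.

Of the compounds shown here, three sharing one core have been tested in a functional assay on NCI-H23 cells (Homo sapiens) for cytotoxicity, read by sulforhodamine B assay, with a stated time of 72 h; a higher number here means a weaker inhibitor of growth, a lower number a stronger inhibitor of growth. Compound 1 `O=C(Nc1ccccc1O)C1CCc2ccccc2N1C(=O)c1ccccc1Cl` gives 46900 nM. Compound 2 `O=C(Nc1ccccc1C(F)(F)F)C1CCc2ccccc2N1C(=O)c1ccccc1`, which carries a trifluoromethylphenyl amide, gives 6340 nM. Compound 3 `CCCCCCCCC(=O)N1c2ccccc2CCC1C(=O)Nc1ccccc1O` gives 55800 nM, the highest number of the three; compound 1 sits within the scatter of it, while compound 2 lies well below it, beyond the scatter.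

Compound 4 `O=C(Nc1ccccc1O)C1CCc2ccccc2N1C(=O)c1ccccc1` has not been measured. It differs from compound 3 by phenyl in place of octyl on a carbonyl carbon. Among the measured compounds shown here, the only measured step touching this position is a 1.2-fold higher number from compound 1 to compound 3 (0.08 log units; within the scatter), a change that hardly moved the number. For the measured compounds named here, compound 2 shows that a benzoyl group can sit alongside a much lower number, but its amide end differs, so no step links it directly to compound 4. The step of a 1.4-fold lower number from compound 3 to compound 4 (0.14 log units; within the scatter) is therefore expected to be small and, if anything, downward. Compound 4 is estimated at 40000 nM, with a likely range from 12000 nM to 120000 nM.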

Compound 4, concentration for 50% growth inhibition: 3490 nM
The estimate for compound 4 lay 11-fold (1.06 log units) above the measured number, and the stated range ends above it.
By their numbers in this assay, from the lowest: compounds 4 and 2 (each within the scatter of the next); then compounds 1 and 3 (each within the scatter of the next).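

In this assay the group on this carbonyl carbon turns out to matter a great deal, since phenyl in place of octyl gives a 16-fold lower number from compound 3 to compound 4 (1.20 log units; beyond the scatter) even though the earlier swap of 2-chlorophenyl for octyl gave only a 1.2-fold higher number from compound 1 to compound 3 (0.08 log units; within the scatter) and no real movement. The low number belongs to plain phenyl and not to any aromatic ring at this place, for hydrogen in place of chloro gives a 13-fold lower number from compound 1 to compound 4 (1.13 log units; beyond the scatter) as a large step of its own. At the other end of the molecule, with the benzoyl group in place, hydroxy in place of trifluoromethyl gives a 1.8-fold lower number from compound 2 to compound 4 (0.26 log units; within the scatter) and so shows no real difference.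

From the compounds shown here alone, whether a methyl, a methoxy or an amine on the phenyl ring would keep the number this low remains open, as does the effect of a chain shorter than octyl. Nothing available explains why these steps differ so sharply in size.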